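The source may report more compounds than this note shows. Statements on the series, on what has been measured and on what is new or still open speak of the compounds shown alone.

Of the compounds shown here, two sharing one core have been measured in a functional assay on HT-1080 cells (Homo sapiens), read by transwell migration, with a stated time of 24 h, tested at 0.1 uM; on this read-out lower numbers stand for a stronger effect and higher numbers for a weaker effect at the one concentration tested. Compound 1, `CC(=O)OCc1ccc2oc(=O)c(C(=O)Nc3cccc(Cl)c3)cc2c1`, gives 79.6%. For the measured compounds named here, compound 2, `CCCC(=O)OCc1ccc2oc(=O)c(C(=O)Oc3cccc(Br)c3)cc2c1`, gives 88.6%; no measured compound gives a larger number, yet the value of compound 1 lies within the scatter of it, so the two cannot be told apart. Compound 3, `CC(C)(C)C(=O)OCc1ccc2oc(=O)c(C(=O)Oc3cccc(Br)c3)cc2c1`, has not yet been measured in this assay. How compound 3 differs from compound 2: tert-butyl in place of propyl on a carbonyl carbon. Going by the values given here, no measured step covers such a change, so the expected step from compound 2 to compound 3 is none beyond the scatter, a number 1.6 percentage points lower from compound 2 to compound 3 (within the scatter). Compound 3 is therefore estimated at 87%, with a range from 74% to 98%.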

Compound 3, a percentage reported as activity, at one concentration (the size of the read-out at that concentration, not a potency): 65.2%
Estimate against measurement, compound 3: 21.8 percentage points above, outside the stated range (below it).
By their numbers in this assay, from the lowest: compound 3; then compounds 1 and 2 (each within the scatter of the next).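

With tert-butyl in place of propyl on a carbonyl carbon, this assay shows a number 23.4 percentage points lower from compound 2 to compound 3 (beyond the scatter). For the compounds shown here, compound 1 and compound 2 differ in more than one place and could not show this, so this is the first sign that the group at this position can alter the read-out. No available evidence bears on the reason for this step.

The compounds shown leave open whether a longer chain, a phenyl ring or an amine at this position would go further. They also leave open whether tert-butyl would act alike alongside the chlorophenyl amide of compound 1.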